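Swapping Fluoro for Bromo: An Expected Step

This account rests on a few compounds, and the source may have more. Where it says the series, first, only, none or still open, it means among the compounds named here.

Measured compounds:
compound 1 `O=C1/C(=C/c2ccccn2)CCc2c(O)cccc21`: 740 nM
compound 2 `O=C1/C(=C/c2ccc(F)cc2)CCc2ccc(O)cc21`: 840 nM

In a functional assay on RAW264.7 cells (Mus musculus) for inhibition (a higher number here means a weaker inhibitor, a lower number a stronger inhibitor), compound 2 gives 840 nM, the higher of the two numbers, while compound 1 gives 740 nM, a gap that lies within the scatter. Compound 3 `O=C1/C(=C/c2ccc(Br)cc2)CCc2ccc(O)cc21` differs from compound 2 by bromo in place of fluoro on an aromatic carbon. Among the compounds with values here, no measured pair shows this change, so in this assay a step from compound 2 to compound 3 not beyond the scatter is expected, leaning if anything toward a lower number. The expected step is a 1.4-fold lower number from compound 2 to compound 3 (0.15 log units; within the scatter). Compound 3 is thus estimated at 600 nM, between 250 nM and 1500 nM.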

Compound 3, half-maximal inhibitory concentration: 800 nM
The estimate for compound 3 lay 1.3-fold (0.12 log units) below the measured number; the measured number falls inside the stated range.
By their numbers in this assay, from the lowest: compounds 1, 3 and 2 (each within the scatter of the next).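

In this assay the exchange of bromo in place of fluoro on an aromatic carbon, para to a large group, gives a 1.1-fold lower number from compound 2 to compound 3 (0.02 log units; within the scatter) and so separates these two halogens at this position by no more than the scatter. The earlier compounds shown here, with only fluoro there, could not show this. No available evidence accounts for the result.

From the compounds shown here alone, whether an amine, a methoxy group or a carboxylic acid at this position would leave the number equally undisturbed remains open. So does the effect of plain hydrogen there.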